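A few compounds are considered here, and "the series" means these few. Any claim that something is new, unique, unknown or untested is made for them only; others in the source may bear on it.

Compound 1 `CC(C)(C)NCc1c(C(=O)O)nn(-c2ccccc2)c1-c1ccc(Cl)cc1`: > 652000 nM
Compound 2 `CC(C)(C)NCc1c(C(=O)O)nn(-c2ccccc2)c1-c1ccc(Br)cc1`: > 585000 nM

Both entries are limits of the assay, not numbers. In a functional assay on 786-0 cells (Homo sapiens) for inhibition, read by sulforhodamine B assay, with a stated time of 48 h (a higher number here means a weaker inhibitor of growth, a lower number a stronger inhibitor of growth), compound 2 gives > 585000 nM, which is a limit. Compound 2 therefore has no exact place on the scale, and the only other result available, for compound 1, is also a limit.

The next compound is compound 3 `CC(C)(C)NCc1c(C(=O)O)nn(-c2ccccc2)c1-c1ccccc1`. It differs from compound 2 as follows: hydrogen in place of bromo on an aromatic carbon. This puts hydrogen in place of bromo on an aromatic carbon, para to a large group, turning 4-bromophenyl into phenyl.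

Among the measured compounds shown here, only one measured step bears on this change: a step that the two limits leave unreadable from compound 1 to compound 2. It swaps one halogen for another at the same place, and its size cannot be read. It therefore gives no measured size or direction to carry over to the removal of bromo. The expectation for compound 3 is no step beyond the usual scatter, and most likely another limit rather than a number in this assay. The expected step is a step that the limit leaves unreadable from compound 2 to compound 3. For compound 3 the estimated value is 715000 nM, with an expected range from 300000 nM to 1000000 nM.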

Compound 3, concentration for 50% growth inhibition: > 716000 nM
Compound 3: a limit, no number (the forecaster's own chance of this, stated with the estimate: 85%); middle value at least 1.0-fold (0.00 log units) away from the limit.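

In this assay, compound 3 gives only a limit, as do compound 1 and compound 2, so the steps from compound 1 to compound 3 and from compound 2 to compound 3 cannot be read. The compounds shown leave open what exact value any of the three has, and whether hydrogen, chloro or bromo at this place changes growth inhibition at all.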